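This account rests on a few compounds, and the source may have more. Where it says the series, first, only, none or still open, it means among the compounds named here.

Measured so far:
compound 1, `Oc1ccc(/C=C/c2ccccc2O)cc1`, 17.5 ug/mL
compound 2, `Nc1ccccc1/C=C/c1ccc(O)cc1`, 7 ug/mL

Among the compounds with values here, compound 2 holds the lower of the two numbers in an ADME assay on HEK293 cells (Homo sapiens) for inhibition, read by MTT assay, with a stated time of 2 days (a higher number here means a weaker inhibitor, a lower number a stronger inhibitor), and the one measured step, a 2.5-fold lower number from compound 1 to compound 2 (0.40 log units; beyond the scatter), is modest. Compound 3, `COc1ccccc1/C=C/c1ccc(O)cc1`, differs from compound 2 by methoxy in place of amino on an aromatic carbon. Within the data shown here, no measured step touches a methoxy group, so the hydroxy-to-amino step bears on this change only loosely, and compound 2 alone anchors the expectation. The step of a 1.6-fold higher number from compound 2 to compound 3 (0.20 log units; within the scatter) is expected to stay small, likely within the scatter. Compound 3 is therefore estimated at 11 ug/mL, in the range 5 ug/mL to 28 ug/mL.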

Compound 3, half-maximal inhibitory concentration: 41 ug/mL
The estimate for compound 3 lay 3.7-fold (0.57 log units) below the measured number, outside the stated range (above it).
By their numbers in this assay, from the lowest: compound 2; then compound 1; then compound 3.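

In this assay, the group on this aromatic carbon matters more than the first pair showed: methoxy in place of amino gives a 5.9-fold higher number from compound 2 to compound 3 (0.77 log units; beyond the scatter). Capping the hydroxy oxygen of compound 1 with methyl also moves the number up, giving a 2.3-fold higher number from compound 1 to compound 3 (0.37 log units; beyond the scatter), so amino, hydroxy and methoxy are all separated here, with methoxy highest. No evidence at hand accounts for these steps.

Still open, from the compounds shown here alone, is whether a longer ether such as ethoxy would follow methoxy at this place. Also open, going by these compounds, is where a fluorine atom or a dimethylamino group would fall.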